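A Fluoro Substituent Added to the Weakest Anilide

The source may hold more compounds than are shown below. What is called first, only, known or untested is meant among the compounds shown, and "the series" means these compounds.

Measured compounds:
compound 1, `Cc1cccc(Cl)c1NC(=O)CN1CCN(c2nnc(Cc3ccncc3)c3ccccc23)CC1`, 7190 nM
compound 2, `O=C(CN1CCN(c2nnc(Cc3ccncc3)c3ccccc23)CC1)Nc1cccc(Br)c1`, 1530 nM
compound 3, `Cc1ccccc1NC(=O)CN1CCN(c2nnc(Cc3ccncc3)c3ccccc23)CC1`, 43100 nM

In a functional assay on A549 cells (Homo sapiens) for cytotoxicity, read by MTT assay, with a stated time of 72 h (on this read-out lower numbers stand for stronger inhibition and higher numbers for weaker inhibition), compound 3 gives 43100 nM, the highest number of the three. Its nearest neighbour is compound 1, which gives 7190 nM; the step of a 6.0-fold higher number from compound 1 to compound 3 (0.78 log units; beyond the scatter) is modest. Compound 2 gives 1530 nM, and the step of a 28-fold higher number from compound 2 to compound 3 (1.45 log units; beyond the scatter) is large. Both steps show that a halogen on the anilide ring goes with a lower number, whether it sits as chloro in compound 1 or as bromo in compound 2.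

Compound 4, `Cc1ccc(F)cc1NC(=O)CN1CCN(c2nnc(Cc3ccncc3)c3ccccc23)CC1`, differs from compound 3 by one change: fluoro in place of hydrogen on an aromatic carbon. This is the same kind of move as the reverse of the step from compound 1 to compound 3, a halogen entering the ring, though fluoro is the smallest of the halogens and sits on a different aromatic carbon than the chloro of compound 1. Going by the values given here, the two halogen-bearing steps give a modest to large lowering, so a modest lowering is expected for compound 4, with uncertainty because only one halogen comparison exists for each ring position.

The estimated step of a 2.9-fold lower number from compound 3 to compound 4 (0.46 log units; beyond the scatter) is expected to be modest. For compound 4 the estimate in this assay is 15000 nM, with a range from 5000 nM to 45000 nM.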

Compound 4, half-maximal inhibitory concentration: 38900 nM
The estimate for compound 4 lay 2.6-fold (0.41 log units) below the measured number; the measured number falls inside the stated range.
By their numbers in this assay, from the lowest: compound 2; then compound 1; then compounds 4 and 3 (each within the scatter of the next).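

In this assay, fluoro on the aromatic carbon para to a methyl group and meta to a large group gives a 1.1-fold lower number from compound 3 to compound 4 (0.04 log units; within the scatter), so this halogen at this position does not show the lowering that went with chloro in compound 1 and bromo in compound 2. Compound 4 also stays well apart from both of those halogen-bearing anilides, with a 25-fold higher number from compound 2 to compound 4 (1.41 log units; beyond the scatter) and a 5.4-fold higher number from compound 1 to compound 4 (0.73 log units; beyond the scatter), which means the earlier link between a halogen on the anilide ring and a lower number does not cover every halogen at every ring position, and compound 4 is the compound that goes against it. Nothing at hand explains this outcome.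

With fluoro as the only halogen shown on this carbon, the compounds leave open whether chloro or bromo there would lower the number, and so whether the halogen or its position sets the outcome. They also leave open how a trifluoromethyl group, a methoxy group or an amine on the same carbon would read in this assay.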